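Moving One Amino Group on a Sulfonamide Side Chain

The compounds below may be only part of what the source reports. "The series", "measured", "known", "first", "only" and "open" are said of these compounds alone.

In a functional assay on the whole organism (arterial blood) with Rattus norvegicus as the target (on this read-out lower numbers stand for an effect already at smaller amounts and higher numbers for an effect only at larger amounts of compound), compound 1 `Cc1nc2cnccc2n1CC1CCN(C(=O)/C=C(\c2ccccc2)c2ccc(N)cc2)CC1` gives 0.01 mg/kg as its result, compound 2 `Cc1nc2cnccc2n1CC1CCN(C(=O)CC(NC(=O)c2ccc(N)cc2)c2ccccc2)CC1` gives 0.19 mg/kg as its result, and compound 3 `CCOC(=O)[C@H](CC(C)C)N(Cc1ccc(N)cc1)S(=O)(=O)c1ccc(Cn2c(C)nc3cnccc32)cc1` gives 0.033 mg/kg as its result. Compound 3 therefore holds the middle place of the three numbers. Its number is higher than that of compound 1 and lower than that of compound 2, and both gaps lie beyond the usual scatter of repeated measurements.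

Compound 4 `CCOC(=O)[C@H](CC(C)C)N(Cc1cccc(N)c1)S(=O)(=O)c1ccc(Cn2c(C)nc3cnccc32)cc1` is the next to be tested. It has 3-aminophenyl in place of 4-aminophenyl on a saturated chain carbon bound to a sulfonamide nitrogen and keeps the same atoms, only joined differently.

Among the measured compounds shown here, no two measured compounds differ in just one place. All three also carry the 4-aminophenyl group, so the data contain no direct measure of this kind of move, and any forecast is a judgement. The rest of the molecule stays untouched, so a large jump seems unlikely. In this assay a small upward move is expected, an estimated 2.1-fold higher number from compound 3 to compound 4 (0.33 log units; beyond the scatter) at about the edge of the scatter, meaning slightly more compound would be needed. For compound 4 the estimated value is 0.07 mg/kg with an expected range from 0.015 mg/kg to 0.3 mg/kg once it is measured.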

Compound 4, dose for 50% inhibition: 0.043 mg/kg
The estimate for compound 4 lay 1.6-fold (0.21 log units) above the measured number; measured number inside the range.
By their numbers in this assay, from the lowest: compound 1; then compounds 3 and 4 (each within the scatter of the next); then compound 2.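

Among the compounds shown here, this pair gives the first comparison in which only one place changes: in this assay, the move to 3-aminophenyl in place of 4-aminophenyl on a saturated chain carbon bound to a sulfonamide nitrogen gives a 1.3-fold higher number from compound 3 to compound 4 (0.11 log units; within the scatter). The earlier compounds shown here all carried 4-aminophenyl, so they could not show whether the read-out depended on that arrangement; on this side chain, the two arrangements cannot be told apart, and the effect does not depend on the 4-aminophenyl form. No measurement shown explains this result.

The compounds shown leave open whether the amino group matters at all on this side chain, which a plain phenyl ring, or a hydroxyl or carboxylic acid in place of the amine, would help to settle. They also leave open whether 3-aminophenyl would be tolerated equally well in the different settings of compound 1 and compound 2, where the 4-aminophenyl group is not attached through a sulfonamide side chain.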